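The compounds below may be only part of what the source reports. "The series", "measured", "known", "first", "only" and "open" are said of these compounds alone.

Values so far in an ADME assay on cells (Hepatocyte, Mus musculus) for cytotoxicity, read by MTT assay, with a stated time of 24 h; on this read-out higher numbers stand for lower toxicity in this test and lower numbers for higher toxicity in this test:
compound 1 (`Cc1ccc(-c2nn(-c3ccccc3)cc2-c2nc3ccccc3n2S(=O)(=O)c2ccccc2)cc1`) gives 189000 nM
compound 2 (`Cc1ccc(-c2nn(-c3ccccc3)cc2-c2nc3ccccc3n2S(=O)(=O)c2ccc(C)cc2)cc1`) gives 102000 nM
compound 3 (`Cc1ccc(-c2nn(-c3ccccc3)cc2-c2nc3ccccc3n2S(=O)(=O)c2ccc(Cl)cc2)cc1`) gives 216000 nM

Compound 3 cannot be separated from compound 1 on these numbers, as a 1.1-fold higher number from compound 1 to compound 3 (0.06 log units; within the scatter) shows. For the measured compounds named here, it stands apart from compound 2 only modestly, and a 2.1-fold higher number from compound 2 to compound 3 (0.33 log units; beyond the scatter) is the one step that clears the scatter.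

The next step leads to compound 4 (`Cc1ccc(-c2nn(-c3ccccc3)cc2-c2nc3ccccc3n2S(=O)(=O)c2ccc(C(F)(F)F)cc2)cc1`), which carries trifluoromethyl in place of chloro on an aromatic carbon. Going by the values given here, no measured compound holds trifluoromethyl, so the read-across is indirect. The closest evidence is the set of small exchanges among compounds 1, 2 and 3. Methyl in place of hydrogen gave a 1.9-fold lower number from compound 1 to compound 2 (0.27 log units; within the scatter) and stayed within the scatter, as did chloro in place of hydrogen. The exception is chloro in place of methyl, which went modestly beyond it.

With steps of this size, no change beyond the scatter is expected in this assay and no firm direction can be assigned. The step expected is a 1.3-fold lower number from compound 3 to compound 4 (0.10 log units; within the scatter) by this estimate. For compound 4 the expected value is 170000 nM with an estimated range from 85000 nM to 320000 nM in this series.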

Compound 4, half-maximal cytotoxic concentration: 89300 nM
Compound 4: the middle estimate sits 1.9-fold (0.28 log units) above what was measured, within the range that was stated.
By their numbers in this assay, from the lowest: compounds 4, 2, 1 and 3 (each within the scatter of the next, the first and the last beyond it).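

In this assay, for the compounds shown here, trifluoromethyl is the first group at this position, para to a large group, to separate from hydrogen (in a 2.1-fold lower number from compound 1 to compound 4 (0.33 log units; beyond the scatter)), whereas methyl and chloro each stayed within the scatter of hydrogen. The exchange also separates trifluoromethyl from chloro (in a 2.4-fold lower number from compound 3 to compound 4 (0.38 log units; beyond the scatter)) but not from methyl (in a 1.1-fold lower number from compound 2 to compound 4 (0.06 log units; within the scatter)), so two groups that both replace hydrogen here need not read alike, and the steps remain modest. No measurement shown here accounts for this grouping.

Still open, from the compounds shown here alone, is where a methoxy group, an amine or a carboxylic acid at this position would fall relative to compound 3 and compound 4 in this assay. Also open, going by these compounds, is whether trifluoromethyl on another carbon of the same ring, or on a different ring of the shared core, would give a step of similar size and direction.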